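This account rests on a few compounds, and the source may have more. Where it says the series, first, only, none or still open, it means among the compounds named here.

In an assay on isolated protein for inhibition of Aromatase (Homo sapiens), read by fluorescence, with stated times of 10 min and 60 min (a higher number here means a weaker inhibitor, a lower number a stronger inhibitor), compound 1, `C#CCOc1ccc(C(=O)c2ccc(Cn3ccnc3)cc2)cc1`, gives 210 nM. Compound 2, `CCCCCOc1ccc(C(=O)c2cccc(Cn3ccnc3)c2)cc1`, is the stronger of the two measured inhibitors: in this assay compound 2 gives 42 nM, the lowest of the two numbers, with compound 1 standing a clear step above it, beyond the usual scatter. Compound 3, `O=C(c1ccc(O)cc1)c1cccc(Cn2ccnc2)c1`, has not yet been measured. It differs from compound 2 in one place: hydrogen in place of pentyl on an oxygen on an aromatic ring, the pentyloxy becoming a hydroxy. For the measured compounds named here, no pair of measured compounds shows what this change does on its own, so the expectation rests on the two values and the structures alone. The step is expected to run toward weaker inhibition, by an amount beyond the scatter: a 9.5-fold higher number from compound 2 to compound 3 (0.98 log units; beyond the scatter). In this assay compound 3 is therefore estimated at 400 nM, within a range from 100 nM to 2000 nM.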

Compound 3, half-maximal inhibitory concentration: 13 nM
For compound 3 the middle estimate is 31-fold (1.49 log units) above the measured one; measured number below the stated range.
By their numbers in this assay, from the lowest: compound 3; then compound 2; then compound 1.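

Removing the pentyl from this oxygen does not cost inhibition in this assay: the change to hydroxy gives a 3.2-fold lower number from compound 2 to compound 3 (0.51 log units; beyond the scatter). The step is modest, but it shows that on this oxygen the pentyl chain is not required for the inhibition seen with compound 2, and that a bare hydroxy does better here. Nothing among the available measurements explains why the hydroxy outperforms the pentyloxy.

The compounds shown leave open whether a methoxy or another short alkoxy group on the same oxygen would fall between these two results, and whether an amine or a carboxylic acid in place of the hydroxy would hold the gain. They also leave open whether the same change would act alike on the core of compound 1, which differs from compound 2 in more than one place.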